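Series notes: amine-bearing side chain swap on the biaryl core

The source may report more compounds than this note shows. Statements on the series, on what has been measured and on what is new or still open speak of the compounds shown alone.

Measured so far in an assay on isolated protein for inhibition of ubiquitin carboxyl-terminal hydrolase 7 (Homo sapiens), read by fluorescence, with stated times of 30 min and 1 h; a lower number here means a stronger inhibitor, a higher number a weaker inhibitor:
compound 1 `Cc1cc(Cl)cc(-c2ccnc3cc(CN4C(=O)CCC4=O)sc23)c1O[C@H]1C[C@H](N)C1`, compound 1 gives 3.4 nM
compound 2 `Cc1cc(Cl)cc(-c2ccnc3cc(CN4C(=O)C5C(C4=O)C5(C)C)sc23)c1C[C@@H]1CNCCO1`, compound 2 gives 0.44 nM
compound 3 `O=C1CCC(=O)N1Cc1cc2nccc(-c3cc(Cl)cc4c3O[C@@H](c3onc5c3CNCC5)C4)c2s1`, compound 3 gives 0.38 nM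

Compound 1 shows the highest number of the three in this assay; compound 2 and compound 3 both sit at lower numbers than compound 1, and the gaps from compound 1 to each of them lie beyond the scatter. Going by the values given here, no pair among the three differs in one place only, so no single step is available from the measured set.

Compound 4 `Cc1cc(Cl)cc(-c2ccnc3cc(CN4C(=O)CCC4=O)sc23)c1CN1CCNC[C@@H]1C` is not yet measured. It differs from compound 1 by (2-methylpiperazin-1-yl)methyl in place of (3-aminocyclobutyl)oxy on an aromatic carbon. The change keeps a ring amine in the side chain, as compound 2 and compound 3 also carry one, while removing the ether oxygen link from compound 1. On that basis the expected direction from compound 1 to compound 4 is towards a somewhat lower number, of a size near the edge of the scatter; the expected step is a 1.7-fold lower number from compound 1 to compound 4 (0.23 log units; within the scatter). Compound 4 is therefore estimated at 2 nM in this assay, within the range 0.5 nM to 8 nM.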

Compound 4, half-maximal inhibitory concentration: 6.6 nM
Compound 4: middle estimate off by 3.3-fold (0.52 log units), on the low side, and the stated range covers the measured number.
By their numbers in this assay, from the lowest: compounds 3 and 2 (each within the scatter of the next); then compounds 1 and 4 (each within the scatter of the next).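

In this assay, (2-methylpiperazin-1-yl)methyl in place of (3-aminocyclobutyl)oxy on this aromatic carbon, ortho to a methyl group and para to a chloro group, gives a 1.9-fold higher number from compound 1 to compound 4 (0.29 log units; within the scatter), so the two side chains are not told apart at this position. The change swaps a four-membered ring of carbon only for a six-membered non-aromatic ring with 2 hetero atoms and removes the ether oxygen, while the counts of hydrogen-bond donors and acceptors stay equal. No measurement available gives a reason for this result.

Open, as far as these compounds go, is whether an acyclic aminomethyl group or a carboxylic acid on the same aromatic carbon would stay within the scatter of compound 1. Also open, from the compounds shown here alone, is what the ring methyl and its stereocentre contribute, compared with a plain piperazine or the opposite configuration.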